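The source may hold more compounds than are shown below. What is called first, only, known or untested is meant among the compounds shown, and "the series" means these compounds.

Compound 1 `CC(=O)O[C@@H]1OC(=O)[C@@](C(C)=O)(C2SCCCS2)[C@@H]1C` in a functional assay on HT-29 cells (Homo sapiens) for cytotoxicity, read by MTT assay (a higher number here means a weaker inhibitor, a lower number a stronger inhibitor), gives > 50000 nM, which is a limit of the assay rather than a number. Compound 2 `CC(=O)O[C@@H]1OC(=O)[C@](OC(C)=O)(C(C)=O)[C@@H]1C` in this assay gives > 50000 nM, again a limit. The step that the two limits leave unreadable from compound 1 to compound 2 is therefore unreadable, and compound 2 stands at the limit of > 50000 nM in this assay, at which 2 of the 2 values shown sit. Compound 3 `CC(=O)O[C@@H]1OC(=O)[C@](Br)(C(C)=O)[C@@H]1C` differs from compound 2 by bromo in place of acetoxy on a saturated ring carbon. No measured step bears on this change, and the one step shown offers no size at all. The step of a number no higher from compound 2 to compound 3 (the limit leaves the size open) is expected to be none beyond the scatter. Compound 3 is thus estimated at 50000 nM, with a range from 10000 nM to 150000 nM.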

Compound 3, half-maximal inhibitory concentration: 12000 nM
Beside the measured number, compound 3's estimate is 4.2-fold (0.62 log units) above it; low and high end bracket the measured number.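

Placing bromo on this saturated ring carbon gives the first measurable response in this assay, with an at least 4.1-fold lower number from compound 2 to compound 3 (0.61 log units; beyond the scatter). Bromine also compares favourably with the larger ring-bearing group at the same position, with an at least 4.1-fold lower number from compound 1 to compound 3 (0.61 log units; beyond the scatter). So this position can change the read-out, whereas the earlier compounds showed only a limit of the assay: the limit of > 50000 nM in this assay, at which 2 of the 3 values shown sit.

From the compounds shown here alone, whether the gain is particular to bromo remains open. Chlorine, an amine or a hydroxyl group at this position could give a higher number, a lower one or a similar one.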